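Cytotoxicity notes: diaryl amide ethers, methoxy addition

The source may hold more compounds than are shown below. What is called first, only, known or untested is meant among the compounds shown, and "the series" means these compounds.

Measured so far:
compound 1 `COc1ccc(C(=O)Nc2ccc(Cl)cc2F)c(OCc2ccc(F)cc2F)c1` — > 40000 nM
compound 2 `O=C(Nc1ccc(F)cc1F)c1ccccc1OCc1ccc(F)cc1F` — > 40000 nM

In an ADME assay on RAW264.7 cells (Mus musculus) for cytotoxicity, read by MTT assay, with a stated time of 24 h (a lower number here means that less compound is tolerated, a higher number that more compound is tolerated), compound 2 gives > 40000 nM, which is a limit of the assay and not a number. Compound 1 also reports a limit in this assay (the limit of > 40000 nM in this assay, at which 2 of the 2 values shown sit). Compound 3 `COc1ccc(C(=O)Nc2ccc(F)cc2F)c(OCc2ccc(F)cc2F)c1` differs from compound 2 by methoxy in place of hydrogen on an aromatic carbon. Compound 1 carries the same methoxy and sits at the limit, so no step beyond the scatter is expected. Compound 3 is expected at 60000 nM, range 30000 nM to 150000 nM, most likely again reported as a limit. The expected step is a step that the limit leaves unreadable from compound 2 to compound 3.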

Compound 3, half-maximal cytotoxic concentration: > 40000 nM
Compound 3: a limit, no number; the forecaster's own chance of this, stated with the estimate: 85%; the middle value lies beyond the limit too.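

No step can be read from compound 2 to compound 3 or from compound 1 to compound 3, because all three compounds sit at the same limit: the limit of > 40000 nM in this assay, at which 3 of the 3 values shown sit.

In this assay the compounds shown leave open at what concentration any of them becomes cytotoxic, and whether either change alters that concentration.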